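The source may report more compounds than this note shows. Statements on the series, on what has been measured and on what is new or still open speak of the compounds shown alone.

Compound 3 `COc1ccc(C(=O)/C=C/c2ccccc2)c2c1C=CC(C)(C)O2` carries a plain phenyl on a double-bonded chain carbon bound to a double-bonded chain carbon. In a functional assay on HepG2 cells (Homo sapiens) for antiproliferative activity, read by MTT assay, with a stated time of 24 h (on this read-out higher numbers stand for weaker inhibition and lower numbers for stronger inhibition), compound 3 gives only a limit, > 10000 nM. Compound 1 `COc1ccc(C(=O)/C=C/c2ccc(N3CCCC3)cc2)c2c1C=CC(C)(C)O2` bears pyrrolidin-1-yl on an aromatic carbon, and in this assay compound 1 gives 4740 nM. Compound 2 `COc1ccc(C(=O)/C=C/c2ccc(-n3ccnc3)cc2)c2c1C=CC(C)(C)O2` bears 1H-imidazol-1-yl on an aromatic carbon. For compound 2 the reading in this assay is again only a limit, > 10000 nM. The step of an at least 2.1-fold higher number from compound 1 to compound 3 (0.32 log units; beyond the scatter) and the step of an at least 2.1-fold higher number from compound 1 to compound 2 (0.32 log units; beyond the scatter) both run toward weaker inhibition, whereas a step that the two limits leave unreadable from compound 2 to compound 3 cannot be sized because the limit of > 10000 nM in this assay, at which 2 of the 3 values shown sit, holds both ends. Compound 4 `COc1ccc(C(=O)/C=C/c2cc(Cl)ccc2O)c2c1C=CC(C)(C)O2` differs from compound 3 in one place: 5-chloro-2-hydroxyphenyl in place of phenyl on a double-bonded chain carbon bound to a double-bonded chain carbon. Going by the values given here, none of the measured steps exchanges phenyl for 5-chloro-2-hydroxyphenyl; they only remove pyrrolidin-1-yl or replace it with 1H-imidazol-1-yl, so they offer little guidance here. The expectation is therefore a step of an at least 1.2-fold lower number from compound 3 to compound 4 (0.09 log units; that floor lies within the scatter) that keeps compound 4 close to the limit. Compound 4 is estimated at 8000 nM, within a range from 2000 nM to 30000 nM.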

Compound 4, half-maximal inhibitory concentration: 6640 nM
Compound 4: middle estimate off by 1.2-fold (0.08 log units), on the high side; low and high end bracket the measured number.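

The earlier compounds shown here gave a readable number at this position only with pyrrolidin-1-yl on the phenyl, and compound 4 shows that 5-chloro-2-hydroxyphenyl also gives a reading within the range of this assay. The change amounts to an at least 1.5-fold lower number from compound 3 to compound 4 (0.17 log units; that floor lies within the scatter), so only a floor is known, and that floor does not separate this change from ordinary scatter. The true size of the step stays unknown because compound 3 gives only a limit, not a number: the limit of > 10000 nM in this assay, at which 2 of the 4 values shown sit.

On these data alone, what stays open is whether the chlorine, the hydroxyl or the two together account for the reading of compound 4. Also open, as far as these compounds go, is how a phenyl bearing only one of them would read, or one bearing an amine or a carboxylic acid instead.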